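The source may hold more compounds than are shown below. What is called first, only, known or untested is meant among the compounds shown, and "the series" means these compounds.

Measured in an in vitro ADME assay on microsomes from liver (Rattus norvegicus) for metabolic stability; on this read-out higher numbers stand for fast clearance and lower numbers for slow clearance:
- Compound 1 `Cc1ccc(Cn2c(=O)[nH]c3c(N)nc(C(F)(F)F)cc32)cn1`: < 8.5 mL.min-1.g-1 (a limit)
- Compound 2 `Cc1ccc(Cn2c(=O)[nH]c3c(N)nc(-n4cccn4)cc32)cn1`: < 8.5 mL.min-1.g-1 (a limit)

Compound 2 reads < 8.5 mL.min-1.g-1, which is a limit of this assay and not a number. The two measured compounds share one reading, (the limit of < 8.5 mL.min-1.g-1 in this assay, at which 2 of the 2 values shown sit), so neither can be placed against the other.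

Compound 3 `CCc1coc(-c2cc3c([nH]c(=O)n3Cc3ccc(C)nc3)c(N)n2)n1` brings a new group onto the shared core: 4-ethyl-1,3-oxazol-2-yl in place of 1H-pyrazol-1-yl on an aromatic carbon. In words, 4-ethyl-1,3-oxazol-2-yl takes the place of 1H-pyrazol-1-yl.

Going by the values given here, the only measured step bearing on this is a step that the two limits leave unreadable from compound 1 to compound 2. It offers no size to carry over and no firm direction. Only a modest rise from the limit of compound 2 is therefore expected, and another limit is quite possible. The expected step is an at least 1.1-fold higher number from compound 2 to compound 3 (0.07 log units; that floor lies within the scatter). For compound 3, the estimated clearance is 10 mL.min-1.g-1, with an expected range from 5 mL.min-1.g-1 to 22 mL.min-1.g-1.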

Compound 3, intrinsic clearance in microsomes in the Rattus norvegicus assay: < 8.5 mL.min-1.g-1
Compound 3: no number, only a limit; the forecaster's own chance of this, stated with the estimate: 45%; middle value at least 1.1-fold (0.07 log units) away from the limit.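

In the Rattus norvegicus assay compound 3 gives < 8.5 mL.min-1.g-1 and this is a limit and not a number. No step can be read between compound 1, compound 2 and compound 3, since all three sit at the same limit: the limit of < 8.5 mL.min-1.g-1 in the Rattus norvegicus assay, at which 3 of the 3 values shown sit.

Going by these compounds, how the clearance of these three compounds truly compares stays open. In a physicochemical assay for lipophilicity, measured as octanol-water partition, at pH 7.4 (a lower number here means a more polar compound, a higher number a more lipophilic compound), compound 2 gives 2.5 as its measured value, and compound 3 gives 3.2 as its measured value.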